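Oxidising a methylsulfanyl group: compound 2 to compound 4

A few compounds are considered here, and "the series" means these few. Any claim that something is new, unique, unknown or untested is made for them only; others in the source may bear on it.

Measured compounds:
compound 1 `CSc1ccc(C)cc1NCC1=NCCN1` 0.912 nM
compound 2 `COc1ccc(SC)c(NCC2=NCCN2)c1` 5.01 nM
compound 3 `CSc1cc(F)ccc1NCC1=NCCN1` 9.12 nM

All three share one core and were tested in a functional assay for agonist activity at Alpha-1D adrenergic receptor (Homo sapiens); a lower number here means that less compound is needed, a higher number that more compound is needed for the effect. Compound 2 gives 5.01 nM there, the second highest of the three numbers. Its nearest neighbour is compound 3 with 9.12 nM, a gap within the scatter, so the two cannot be ranked. Among the compounds with values here, its furthest neighbour is compound 1 with 0.912 nM, and the one step recorded between measured compounds, a 5.5-fold higher number from compound 1 to compound 2 (0.74 log units; beyond the scatter), shows that a methoxy in place of a methyl on an aromatic carbon raised the number beyond the scatter.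

Compound 4 `COc1ccc(S(C)(=O)=O)c(NCC2=NCCN2)c1` is the untested compound. It differs from compound 2 in one place: methylsulfonyl in place of methylsulfanyl on an aromatic carbon. Within the data shown here, none of the measured steps touches the methylsulfanyl group, so there is no direct guide to the size or direction of this change. Among the measured compounds shown here, the only step available, from compound 1 to compound 2, concerns a different position and shows that a single substituent swap on this core can move the number modestly.

Given the larger group entering, compound 4 is expected to give a higher number than compound 2, estimated as a 10-fold higher number from compound 2 to compound 4 (1.00 log units; beyond the scatter). The estimate for compound 4 is 50 nM, within 8 nM to 400 nM.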

Compound 4, half-maximal effective concentration: < 100000 nM
Compound 4: only a limit was reported; the forecaster's own chance of this, stated with the estimate: 10%; the middle value lies beyond the limit too.
By their numbers in this assay, from the lowest: compound 1; then compounds 2 and 3 (each within the scatter of the next).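

In this assay compound 4 gives < 100000 nM, which is a limit and not a number, so the step from compound 2 to compound 4 cannot be read. The compounds shown leave open how far, and in which direction, methylsulfonyl in place of methylsulfanyl moves the number on this core.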